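Working notes: the step from compound 3 to compound 4

The source may report more compounds than this note shows. Statements on the series, on what has been measured and on what is new or still open speak of the compounds shown alone.

Measured in a functional assay on DU-145 cells (Homo sapiens) for inhibition, read by trypan blue exclusion, with a stated time of 96 h; on this read-out higher numbers stand for weaker inhibition of growth and lower numbers for stronger inhibition of growth:
- compound 1 `COc1cc(/C=C(/SCc2ccc(Br)cc2)C(=O)c2ccc(C(=O)O)cc2)ccc1F`: 1000 nM
- compound 2 `O=C(O)c1ccc(C(=O)/C(=C\c2ccc([N+](=O)[O-])c(O)c2)SCc2ccc(Br)cc2)cc1`: 10000 nM
- compound 3 `O=C(O)c1ccc(C(=O)/C(=C\c2ccc(Br)c([N+](=O)[O-])c2)SCc2ccc(Br)cc2)cc1`: 1000 nM

Compound 3 stands at 1000 nM, level with compound 1 at 1000 nM, and these two share the low end of the three numbers. Compound 2 is the outlier, with a 10-fold lower number from compound 2 to compound 3 (1.00 log units; beyond the scatter).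

Compound 4 `CN1CCN(/C=C(/SCc2ccc(Br)cc2)C(=O)c2ccc(C(=O)O)cc2)CC1[N+](=O)[O-]` has not yet been measured in this assay. The change is 4-methyl-3-nitropiperazin-1-yl in place of 4-bromo-3-nitrophenyl on a double-bonded chain carbon bound to a double-bonded chain carbon.

All three measured steps fall at this same place, but each only exchanges one phenyl group for another. The exchange between compound 1 and compound 3 gave no change at the digits printed from compound 1 to compound 3 (within the scatter), whereas the exchange between compound 1 and compound 2 gave a 10-fold higher number from compound 1 to compound 2 (1.00 log units; beyond the scatter). Within the data shown here, no measured compound carries a non-aromatic ring here, so the direction of the step is poorly supported, and the width of the range follows the size of a 10-fold higher number from compound 1 to compound 2 (1.00 log units; beyond the scatter).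

A modest move toward weaker inhibition of growth is expected, with the estimated step being a 3.0-fold higher number from compound 3 to compound 4 (0.48 log units; beyond the scatter).

The estimate for compound 4 is 3000 nM, with an expected range of 500 nM to 15000 nM.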

Compound 4, concentration for 50% growth inhibition: 10000 nM
Compound 4: the middle estimate sits 3.3-fold (0.52 log units) below what was measured, within the range that was stated.
By their numbers in this assay, from the lowest: compounds 1 and 3 (each within the scatter of the next); then compounds 2 and 4 (each within the scatter of the next).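

In this assay, among these compounds, the 4-methyl-3-nitropiperazin-1-yl group of compound 4 is the first non-aromatic ring seen on a double-bonded chain carbon bound to a double-bonded chain carbon, and the exchange gives a 10-fold higher number from compound 3 to compound 4 (1.00 log units; beyond the scatter) and also a 10-fold higher number from compound 1 to compound 4 (1.00 log units; beyond the scatter) on this read-out. The comparison with the remaining phenyl compound gives no change at the digits printed from compound 2 to compound 4 (within the scatter) so a six-membered aromatic ring of carbon only does not by itself set the lower number: the 3-hydroxy-4-nitrophenyl group and the non-aromatic ring stand level, while the 4-bromo-3-nitrophenyl and 4-fluoro-3-methoxyphenyl groups stand level at the lower number. Nothing available bears on why these groups divide in this way.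

The compounds shown leave open whether the higher number follows the non-aromatic ring itself or its methyl and nitro substituents, a question that a plain piperazin-1-yl, a morpholin-4-yl or a cyclohexyl group at this place would address. They also leave open whether the same division between these groups would hold with a methyl ester or a primary amide in place of the carboxylic acid on the shared core.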